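The source may report more compounds than this note shows. Statements on the series, on what has been measured and on what is new or still open speak of the compounds shown alone.

Compound 1 `Oc1cccc(-c2cc(-c3ccccc3F)cc(-c3ccccc3O)n2)c1` gives 31100 nM in a functional assay on HeLa cells (Homo sapiens) for inhibition; a lower number here means a stronger inhibitor, a higher number a weaker inhibitor. Compound 2 `Oc1cccc(-c2cc(-c3ccccc3C(F)(F)F)cc(-c3ccccc3O)n2)c1` gives 16800 nM in this assay, a step of a 1.9-fold lower number from compound 1 to compound 2 (0.27 log units; within the scatter). For compound 3 `Oc1cccc(-c2cc(-c3ccc(C(F)(F)F)cc3)cc(-c3ccccc3O)n2)c1` the this assay reports only a limit, > 50000 nM, so its place is known only as that limit (the limit of > 50000 nM in this assay, at which 1 of the 3 values shown sits). From compound 1 the step is an at least 1.6-fold higher number from compound 1 to compound 3 (0.20 log units; that floor lies within the scatter), and from compound 2 it is an at least 2.9-fold higher number from compound 2 to compound 3 (0.47 log units; beyond the scatter). Compound 4 `Oc1cccc(-c2cc(-c3ccc(C(F)(F)F)cc3)cc(-c3cccc(O)c3)n2)c1` differs from compound 3 by 3-hydroxyphenyl in place of 2-hydroxyphenyl on an aromatic carbon. Going by the values given here, none of the measured steps alters a hydroxyphenyl group; each changes the other aryl group, so they say nothing direct about this move. The expectation for compound 4 is therefore no step beyond the scatter, a step that the limit leaves unreadable from compound 3 to compound 4, with another limit likely. Compound 4 is estimated at 70000 nM, between 20000 nM and 250000 nM.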

Compound 4, half-maximal inhibitory concentration: > 50000 nM
Compound 4: only a limit was reported; the forecaster's own chance of this, stated with the estimate: 70%; the middle value lies beyond the limit too.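

Compound 3 and compound 4 both stand only as limits in this assay, so no step between them can be read: the limit of > 50000 nM in this assay, at which 2 of the 4 values shown sit.

Going by these compounds, whether 3-hydroxyphenyl in place of 2-hydroxyphenyl changes inhibition at all remains open.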